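The source may hold more compounds than are shown below. What is called first, only, known or untested is meant among the compounds shown, and "the series" means these compounds.

Three measured compounds share one core: compound 1 `Nc1cc(N)c2nc(-c3ccccc3)c(NCc3ccc(Cl)c(Cl)c3)nc2c1`, compound 2 `Nc1cc(N)c2nc(-c3ccccc3)c(Oc3ccc(F)cc3)nc2c1` and compound 3 `Nc1cc(N)c2nc(-c3ccccc3)c(Sc3ccc(Cl)c(Cl)c3)nc2c1`. In a functional assay on SK-MEL-5 cells (Homo sapiens) for inhibition, read by sulforhodamine B assay, with a stated time of 48 h (a higher number here means that more compound is tolerated, a lower number that less compound is tolerated), compound 1 gives 34700 nM, and in this assay compound 2 gives 83200 nM. For compound 3 this assay returns only a limit, < 100000 nM, so compound 3 stands on a bound and not on a number. Among the compounds with values here, the single measured step that reaches compound 3, a step that the limit leaves unreadable from compound 2 to compound 3, has no readable size because of the limit of < 100000 nM in this assay, at which 1 of the 3 values shown sits; it is the only step in the set, and it cannot be used to predict either direction or magnitude.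

Compound 4 `Nc1cc(N)c2nc(-c3ccccc3)c(NCc3ccc(F)cc3)nc2c1` has not yet been measured. It differs from compound 3 by (4-fluorobenzyl)amino in place of (3,4-dichlorophenyl)sulfanyl on an aromatic carbon. Within the data shown here, no measured step of a matching kind exists, so the expectation rests on the two numbers given for compound 1 and compound 2, which bracket the likely range, and on the fact that compound 3 itself is known only as a limit. The step that the limit leaves unreadable from compound 3 to compound 4 is therefore expected to be no more than the scatter would allow, with no confident direction. Compound 4 in this assay is estimated at 55000 nM, with a range from 20000 nM to 100000 nM.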

Compound 4, concentration lethal to 50% of the cells: 6920 nM
Compound 4: middle estimate off by 7.9-fold (0.90 log units), on the high side, and the stated range ends above it.
By their numbers in this assay, from the lowest: compound 4; then compound 1; then compound 2.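

Compound 4 gives this position its first readable steps in this assay, and they show that less compound is tolerated with a (4-fluorobenzyl)amino group here. Taking the place of 4-fluorophenoxy, this group gives a 12-fold lower number from compound 2 to compound 4 (1.08 log units; beyond the scatter). The position also responds to the ring at the end of the amino chain, not only to the atom that links it to the core: with the chain kept, 4-fluorophenyl in place of 3,4-dichlorophenyl gives a 5.0-fold lower number from compound 1 to compound 4 (0.70 log units; beyond the scatter). The step to compound 4 from the (3,4-dichlorophenyl)sulfanyl compound, compound 3, cannot be read, because compound 3 stands on a limit: the limit of < 100000 nM in this assay, at which 1 of the 4 values shown sits.

The step from compound 2 swaps the linking oxygen for an amino group and adds a chain carbon in one move, so the compounds shown do not separate these two changes, and they do not say whether the fluorine or the loss of the two chlorines drives the step from compound 1. From the compounds shown here alone, how a plain benzylamino group, a 4-chlorobenzylamino group or a longer chain such as 2-phenylethylamino would read at this position remains open.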